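Replacing one side group on the weakest of three compounds

The source may hold more compounds than are shown below. What is called first, only, known or untested is meant among the compounds shown, and "the series" means these compounds.

In a functional assay on NCI-H460 cells (Homo sapiens) (a lower number here means that less compound is needed, a higher number that more compound is needed for the effect), compound 1 `COc1cc(C2OC(c3ccc(N(C)C)cc3)=NN2C(C)=O)cc(OC)c1OC(C)=O` gives 13 uM and compound 2 `COC(=O)c1c(OC)cc(C2OC(c3ccc(N)c(C)c3)=NN2C(C)=O)cc1OC` gives 0.51 uM while compound 3 `CCOC(=O)C(=O)N1N=C(c2ccc(N(C)C)cc2)OC1c1cc(OC)c(OC)c(OC)c1` stands at 33 uM as the highest of the three numbers. More of compound 3 is therefore needed for the effect than of either other compound, and both gaps lie beyond the usual scatter.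

Compound 4 `COc1cc(C2OC(c3ccc(N(C)C)cc3)=NN2C(=O)CNC(C)=O)cc(OC)c1OC` has not yet been measured. It differs from compound 3 in one place, with acetamidomethyl in place of ethoxycarbonyl on a carbonyl carbon. Within the data shown here, no two measured compounds differ in only one place, so nothing shows directly what this change does. The expectation is therefore cautious, and it leans on compound 1 at 13 uM as the nearest value to compound 3. A small move toward a lower number is expected in this assay rather than a large one. The expected change is a 2.2-fold lower number from compound 3 to compound 4 (0.34 log units; beyond the scatter) and it remains uncertain. The estimate for compound 4 is 15 uM with an expected range from 4 uM to 50 uM for the coming measurement.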

Compound 4, concentration for half-maximal effect: 0.48 uM
For compound 4 the middle estimate is 31-fold (1.49 log units) above the measured one; the measured number lies below the stated range.
By their numbers in this assay, from the lowest: compounds 4 and 2 (each within the scatter of the next); then compound 1; then compound 3.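

In this assay the change to acetamidomethyl in place of ethoxycarbonyl on a carbonyl carbon gives a 69-fold lower number from compound 3 to compound 4 (1.84 log units; beyond the scatter) and is the only direct reading of a single change among these compounds. It shows that the group on this carbonyl carbon can, on its own, move the number a long way, even though the two groups have the same count of heavy atoms and neither contains a ring. What differs in the counts is that acetamidomethyl brings a nitrogen and a hydrogen-bond donor, but no measurement here connects either of them to the step.

Going by these compounds, whether a plain aminomethyl group, a carboxylic acid or a longer chain ending in the same amide would give a similarly low number remains open. This single step also leaves open whether the same change would have a similar effect on a different core.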